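This account rests on a few compounds, and the source may have more. Where it says the series, first, only, none or still open, it means among the compounds named here.

Values in an ADME assay on MT4 cells (Homo sapiens) for cytotoxicity, read by MTT assay, with a stated time of 5 days; a lower number here means that less compound is tolerated, a higher number that more compound is tolerated:
- Compound 1 `N#Cc1ccc(Nc2nccc(OCC(=O)Nc3ccc(Cl)cc3)n2)cc1`: 162000 nM
- Compound 2 `N#Cc1ccc(Nc2nccc(OCC(=O)Nc3ccc(C#N)cc3F)n2)cc1`: > 321000 nM, a limit of the assay
- Compound 3 `Cc1cc(OCC(=O)Nc2ccc(Cl)cc2)nc(Nc2ccc(C#N)cc2)n1`: 2630 nM

Compound 3 holds the lower of the two actual numbers in this assay, since the value for compound 2 is only a limit. The gap between those two numbers is a 62-fold lower number from compound 1 to compound 3 (1.79 log units; beyond the scatter), and it comes with methyl in place of hydrogen on an aromatic carbon.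

Compound 4 `Cc1cc(OCC(=O)Nc2ccc(C#N)cc2)nc(Nc2ccc(C#N)cc2)n1` keeps that methyl and carries cyano in place of chloro on an aromatic carbon. The closest measured step is an at least 1.9-fold higher number from compound 1 to compound 2 (0.29 log units; that floor lies within the scatter), with 4-cyano-2-fluorophenyl in place of 4-chlorophenyl on an amide-type nitrogen. That step is only a floor and also brings in fluorine, so it offers weak guidance towards a higher number. The methyl step concerns a part of the structure that stays the same, so compound 4 should remain much nearer to compound 3 than to compound 1.

The expected step is a 1.9-fold higher number from compound 3 to compound 4 (0.28 log units; within the scatter), a modest rise that is not expected to reach clearly beyond the scatter. Compound 4 is estimated at 5000 nM, with an expected range from 1500 nM to 40000 nM.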

Compound 4, half-maximal cytotoxic concentration: > 325000 nM
Compound 4 was reported as a limit; the forecaster's own chance of this, stated with the estimate: 15%; at least 65-fold (1.81 log units) between middle value and limit.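

In this assay, with the methyl kept on the shared core, cyano in place of chloro gives an at least 120-fold higher number from compound 3 to compound 4 (2.09 log units; beyond the scatter), so the low number of compound 3 does not come from the methyl alone. The earlier change on this same aryl group, an at least 1.9-fold higher number from compound 1 to compound 2 (0.29 log units; that floor lies within the scatter), was only a floor within the scatter and also brought in fluorine, whereas this step changes chloro to cyano alone and lies beyond the scatter. The size of the step remains a floor because the value of compound 4 is a limit of the assay and not a number: the limit of > 325000 nM in this assay, at which 1 of the 4 values shown sits.

The compounds shown leave open how the same chloro-to-cyano change behaves on the core without the methyl, as no pair isolates it there. Also open, as far as these compounds go, is whether another group at this place on the aromatic ring, such as an amine or a carboxylic acid, or a longer chain in place of the methyl, would keep the number at the level of compound 4 or bring it back towards that of compound 3.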